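Swapping the aryl group on the carbonyl in a cytotoxicity series

The source may report more compounds than this note shows. Statements on the series, on what has been measured and on what is new or still open speak of the compounds shown alone.

Compound 2 `Cc1ccc(N(C(=O)c2cc(F)ccc2F)C(=S)OCCN2C(=O)c3ccccc3C2=O)cc1` and compound 1 `Cc1ccc(C(=O)N(C(=S)OCCN2C(=O)c3ccccc3C2=O)c2ccc(C)cc2)cc1` share a common core and differ only in the aryl group attached to a carbonyl carbon. In an ADME assay on MT4 cells (Homo sapiens) for cytotoxicity, read by MTT assay (a lower number here means that less compound is tolerated, a higher number that more compound is tolerated), compound 1 gives 83000 nM, while compound 2 gives 62000 nM. Compound 2 thus holds the lower of the two numbers, but the step of a 1.3-fold lower number from compound 1 to compound 2 (0.13 log units; within the scatter) lies within the scatter, so the two compounds cannot be told apart on these numbers.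

Compound 3 `Cc1ccc(N(C(=O)c2ccc([N+](=O)[O-])cc2Cl)C(=S)OCCN2C(=O)c3ccccc3C2=O)cc1` is the next variation at the same position: 2-chloro-4-nitrophenyl in place of 2,5-difluorophenyl on a carbonyl carbon. For the measured compounds named here, the only step that bears on this change is the earlier aryl swap at the same carbonyl carbon, a 1.3-fold lower number from compound 1 to compound 2 (0.13 log units; within the scatter), which did not move the number beyond the scatter. A similar outcome is therefore expected for compound 3, with the expected step of a 1.1-fold lower number from compound 2 to compound 3 (0.05 log units; within the scatter). The estimate for compound 3 in this assay is 55000 nM, in the range from 25000 nM to 120000 nM.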

Compound 3, half-maximal cytotoxic concentration: 17000 nM
The estimate for compound 3 lay 3.2-fold (0.51 log units) above the measured number; the whole stated range lies above it.
By their numbers in this assay, from the lowest: compound 3; then compounds 2 and 1 (each within the scatter of the next).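

The aryl group on the carbonyl carbon is not a neutral position in this assay: 2-chloro-4-nitrophenyl in place of 2,5-difluorophenyl gives a clear drop (a 3.6-fold lower number from compound 2 to compound 3 (0.56 log units; beyond the scatter)), and 2-chloro-4-nitrophenyl in place of 4-methylphenyl gives a similar one (a 4.9-fold lower number from compound 1 to compound 3 (0.69 log units; beyond the scatter)). For the compounds shown here, the earlier aryl swap stayed within the scatter, so this is the first sign that a change at this carbon can lower the amount of compound the cells tolerate, though both steps are modest. Nothing available here explains the drop.

The new group brings in chlorine and a nitro group together, so these compounds leave open whether one of them alone accounts for the step. Nor do they show how a phenyl ring carrying an amine or a carboxylic acid would behave at this position.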